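Cyano for chloro on the shared core, hepatic extraction

The compounds below may be only part of what the source reports. "The series", "measured", "known", "first", "only" and "open" are said of these compounds alone.

Working notes on the series. Compound 2 `CCC(CC)n1c(=O)[nH]c2ncc(Cl)nc21` is followed here in an ADME assay on microsomes from liver (Rattus norvegicus), read by LC-MS, with a stated time of 90 min; on this read-out higher numbers stand for higher hepatic extraction and lower numbers for lower hepatic extraction. Compound 2 gives 0.4. Compound 1 `CC[C@H](C)n1c(=O)[nH]c2ncc(Br)nc21` gives 0.3, which sits within the scatter of compound 2. Compound 3 `C#Cc1cnc2nc(O)n(C(CC)CC)c2n1` gives 0.26, a gap from compound 2 that lies beyond the scatter. Among the compounds with values here, no two measured compounds differ in one place, so no single step can be read among them. Compound 4 `CCC(CC)n1c(=O)[nH]c2ncc(C#N)nc21` differs from compound 2 in one way: cyano in place of chloro on an aromatic carbon. No comparable change stands among the measured compounds, and the expected step is a number 0.080 lower from compound 2 to compound 4 (within the scatter), small and possibly nothing beyond the scatter. Compound 4 is therefore estimated at 0.32, in the range 0.2 to 0.45.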

Compound 4, hepatic extraction ratio: < 0.2
Compound 4 gave a limit, no number (the forecaster's own chance of this, stated with the estimate: 5%); at least 0.12 between middle value and limit.
By their numbers in this assay, from the lowest: compounds 3, 1 and 2 (each within the scatter of the next, the first and the last beyond it). At a limit, below all of these: compound 4.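

In this assay, within the data shown here, cyano in place of chloro on an aromatic carbon gives a number at least 0.20 lower from compound 2 to compound 4 (beyond the scatter) as the first step that can be read at one place. This aromatic carbon, next to the ring nitrogen, therefore responds to a change of group beyond the scatter. Compound 4 stands at a limit and not a number, so the step has a floor but no fixed size: the limit of < 0.2 in this assay, at which 1 of the 4 values shown sits.

From the compounds shown here alone, an amine or a methoxy group on this carbon remains open. So does whether cyano for chloro gives a similar step on a chain other than the one shared by compound 2 and compound 4.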